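This account rests on a few compounds, and the source may have more. Where it says the series, first, only, none or still open, it means among the compounds named here.

Compound 1 `Cn1c(-c2ccc(NC(=O)CSc3nc4ccccc4o3)cc2)nc(-c2ccccc2)c1-c1ccccc1`: in a functional assay on HT-29 cells (Homo sapiens) for cytotoxicity, read by MTT assay, with a stated time of 24 h, tested at 6.4 ug/mL (a lower number here means a weaker effect, a higher number a stronger effect of the compound at the concentration tested), compound 1 gives 44.9%.
Compound 2 `CCN1CCN(CC(=O)Nc2ccc(-c3nc(-c4ccccc4)c(-c4ccccc4)n3C)cc2)CC1`: in this assay compound 2 gives 17.2%.

Of these two numbers, compound 2 holds the lower one. Going by the values given here, the single measured step, a number 27.7 percentage points lower from compound 1 to compound 2 (beyond the scatter), lies beyond the scatter, but it concerns a different part of the molecule from the change now considered. Compound 3 `COc1ccc(CN2CCN(CC(=O)Nc3ccc(-c4nc(-c5ccccc5)c(-c5ccccc5)n4C)cc3)CC2)cc1` keeps the whole of compound 2 except for one change: 4-methoxyphenyl in place of methyl on a saturated chain carbon bound to an amine nitrogen in a ring. Among the compounds with values here, no measured pair shows what happens when the group on that ring nitrogen is made larger in this way, so the only guide is that the core and the amide linkage are unchanged. The step from compound 2 to compound 3 in this assay is therefore expected to stay within the scatter, and the estimate for the step is a number 2.8 percentage points higher from compound 2 to compound 3 (within the scatter). For compound 3 the expected value in this assay is 20%, with a plausible range from 8% to 40%.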

Compound 3, a percentage reported as activity, at one concentration (the size of the read-out at that concentration, not a potency): 17.8%
Estimate against measurement, compound 3: 2.2 percentage points above; low and high end bracket the measured number.
By their numbers in this assay, from the lowest: compounds 2 and 3 (each within the scatter of the next); then compound 1.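

In this assay, the step on the saturated chain carbon bound to an amine nitrogen in a ring, with 4-methoxyphenyl in place of methyl, gives a number 0.6 percentage points higher from compound 2 to compound 3 (within the scatter). Going by these compounds alone, this is the first measured change at this position, and it shows that, for this one pair, the group on the ring nitrogen can go from ethyl to 4-methoxybenzyl, bringing in a six-membered aromatic ring and a methoxy oxygen, while the two compounds remain indistinguishable in this read-out. Nothing available explains why these two compounds read alike.

One pair cannot show whether this tolerance extends to other groups on that ring nitrogen, such as a carboxylic acid or a longer alkyl chain. It also leaves open whether the methoxy group itself matters, which a plain benzyl group there could test.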